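Swapping the Methyl-Oxadiazole for an Amino-Thiadiazole

The source may report more compounds than this note shows. Statements on the series, on what has been measured and on what is new or still open speak of the compounds shown alone.

Compound 3 `Cc1nnc(SCc2coc3ccccc3c2=O)o1` carries a 5-methyl-1,3,4-oxadiazol-2-yl group on a sulfur whose other neighbour is a saturated chain carbon. In a functional assay on MCF7 cells (Homo sapiens) for cytotoxicity, read by MTT assay, with a stated time of 72 h (a lower number here means a stronger inhibitor, a higher number a weaker inhibitor), compound 3 gives 4600 nM, the lowest of the two numbers at hand. The nearest is compound 1 `Cc1nnc(SCc2coc3ccc(Cl)cc3c2=O)o1`, which in this assay gives 5000 nM; the step of a 1.1-fold lower number from compound 1 to compound 3 (0.04 log units; within the scatter) shows that removing the chloro changes little. Compound 2 `Nc1nc(SCc2coc3ccccc3c2=O)n[nH]1` carries a 5-amino-1H-1,2,4-triazol-3-yl group on that sulfur. In this assay compound 2 reaches only the limit > 25000 nM. The step of an at least 5.4-fold lower number from compound 2 to compound 3 (0.73 log units; beyond the scatter) is therefore the one that bears on what follows.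

Compound 4 `Nc1nnc(SCc2coc3ccccc3c2=O)s1` differs from compound 3 in one place: 5-amino-1,3,4-thiadiazol-2-yl in place of 5-methyl-1,3,4-oxadiazol-2-yl on a sulfur. An amino group on a five-membered ring with three hetero atoms returns, as in compound 2. The step of an at least 5.4-fold lower number from compound 2 to compound 3 (0.73 log units; beyond the scatter) ran toward lower numbers when such a ring left, so the reverse direction is expected now, and one of the three values already sits at the limit of > 25000 nM in this assay, at which 1 of the 3 values shown sits, where compound 4 might also land. Compound 4 is expected in this assay at 15000 nM, within a range from 5000 nM to 40000 nM. The expected step is a 3.3-fold higher number from compound 3 to compound 4 (0.51 log units; beyond the scatter), upward and beyond the scatter.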

Compound 4, half-maximal inhibitory concentration: > 25000 nM
Compound 4 was reported as a limit; the forecaster's own chance of this, stated with the estimate: 40%; middle value at least 1.6-fold (0.22 log units) from the limit.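

The step of an at least 5.4-fold higher number from compound 3 to compound 4 (0.73 log units; beyond the scatter) shows that in this assay a second amino-bearing ring on this sulfur also goes with a weaker result, so the loss is not confined to the 5-amino-1H-1,2,4-triazol-3-yl group of compound 2. Among the compounds shown, the two with a measured number, compound 1 and compound 3, both carry 5-methyl-1,3,4-oxadiazol-2-yl on this sulfur, while the two with an amino-bearing ring, compound 2 and compound 4, give no number, and no compound here goes against that split. Compound 2 and compound 4 each stand at a limit rather than a number, so the step between them cannot be read, and whether their two rings differ stays unknown: the limit of > 25000 nM in this assay, at which 2 of the 4 values shown sit.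

This swap changes two things at once, the ring oxygen becoming sulfur and the methyl becoming amino, and the data do not tell which of the two goes with the loss. A 5-methyl-1,3,4-thiadiazol-2-yl or a 5-amino-1,3,4-oxadiazol-2-yl group on the same sulfur would separate the two changes.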